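The compounds below may be only part of what the source reports. "The series", "measured", "known", "first", "only" and "open" are said of these compounds alone.

Measured compounds, with their numbers in an assay on microsomes from liver for inhibition of sterol O-acyltransferase 1 (Rattus norvegicus); on this read-out lower numbers stand for stronger inhibition and higher numbers for weaker inhibition:
compound 1, `C[C@@]1(O)CC(=O)OC(CSc2nc(-c3ccccc3)c(-c3ccccc3)[nH]2)C1`; compound 1 gives 170 nM
compound 2, `CC1(C)CC(=O)OC(CSc2nc(-c3ccccc3)c(-c3ccccc3)[nH]2)C1`; compound 2 gives 100 nM

For the measured compounds named here, compound 2 holds the lower of the two numbers in this assay, but its only neighbour is compound 1, and the step of a 1.7-fold lower number from compound 1 to compound 2 (0.23 log units; within the scatter) lies within the scatter, so the two compounds cannot be put in order on this read-out.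

The unmeasured compound 3, `c1ccc(-c2nc(SCC3OCCCO3)[nH]c2-c2ccccc2)cc1`, differs from compound 2 in that (a group of 6 heavy atoms (4 carbon, 2 oxygen; one six-membered non-aromatic ring with 2 hetero atoms) in place of a group of 9 heavy atoms (7 carbon, 2 oxygen; one six-membered non-aromatic ring with 1 hetero atom), on a saturated chain carbon bound to a sulfur). Going by the values given here, the single measured step, a 1.7-fold lower number from compound 1 to compound 2 (0.23 log units; within the scatter), concerns a change inside the ring with 1 hetero atom, not its exchange for a ring with 2 hetero atoms, so it bears on the present step only loosely: it shows once that a change at the saturated chain carbon bound to a sulfur left the number within the scatter. Among the compounds with values here, no measured pair speaks to the loss of the double bond outside aromatic rings. The expected step is therefore small and uncertain in direction, a 2.2-fold higher number from compound 2 to compound 3 (0.34 log units; beyond the scatter), with a wide range. For compound 3 in this assay the estimate is 220 nM, between 70 nM and 700 nM.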

Compound 3, half-maximal inhibitory concentration: 180 nM
Compound 3: the middle estimate sits 1.2-fold (0.09 log units) above what was measured; low and high end bracket the measured number.
By their numbers in this assay, from the lowest: compounds 2, 1 and 3 (each within the scatter of the next).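

Compounds 1 and 2 differ only inside the ring with 1 hetero atom, whereas compound 3 exchanges that ring for a ring with 2 hetero atoms and also lacks the double bond outside aromatic rings. In this assay this exchange, on a saturated chain carbon bound to a sulfur, gives a 1.8-fold higher number from compound 2 to compound 3 (0.26 log units; within the scatter) and, with the other ring as the starting point, a 1.1-fold higher number from compound 1 to compound 3 (0.02 log units; within the scatter), so all three compounds lie within the scatter of one another and cannot be put in order. No supporting data are available to account for this result.

All three compounds carry a six-membered non-aromatic ring at this place, so these numbers say nothing about an open chain such as a longer alkyl chain, or about an amine or a carboxylic acid, in its stead. Going by these compounds, it also remains open whether any group on this saturated chain carbon bound to a sulfur can produce a step beyond the scatter in this assay, in either direction.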